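Ester to acid on a shared thiophene-free core, a guess

The source may hold more compounds than are shown below. What is called first, only, known or untested is meant among the compounds shown, and "the series" means these compounds.

Two close relatives have been tested in a functional assay, with a stated time of 150 min, tested at 15 ug/mL; a lower number here means a weaker effect, a higher number a stronger effect of the compound at the concentration tested. Compound 1, `COC(=O)c1c(Nc2ccc(C)cc2)sc(C(=O)c2ccc(OC)cc2)c1C`, was reported as "not active" (no number reported) without a number. Compound 2, `COC(=O)c1c(Nc2ccc(OC)cc2)sc(C(=O)c2ccc(OC)cc2)c1C`, gave 7.8%, the only figure available, and it stands low on that scale, a weak effect at the concentration used. Compound 3, `COc1ccc(Nc2sc(C(=O)c3ccc(OC)cc3)c(C)c2C(=O)O)cc1`, has not yet been measured. It differs from compound 2 in one place: hydrogen in place of methyl on an oxygen next to a carbonyl group. Among the measured compounds shown here, no step between two measured compounds with a single number is available, so the size of such a change cannot be read from this set. With compound 2 already weak, the change from compound 2 to compound 3 is expected to stay within the usual scatter, as the step of a number 1.8 percentage points lower from compound 2 to compound 3 (within the scatter) expresses. Compound 3 is therefore estimated at 6%, with a range from 0% to 18%.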

Compound 3, a percentage reported as activity, at one concentration (the size of the read-out at that concentration, not a potency): 30.6%
Estimate against measurement, compound 3: 24.6 percentage points below; measured number above the stated range.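

Changing methoxycarbonyl to carboxy gives a number 22.8 percentage points higher from compound 2 to compound 3 (beyond the scatter) in this assay. Among the compounds shown here, this is the first readable step in the set, and it shows that this position is not indifferent: losing a single methyl from an oxygen next to a carbonyl group is enough to move the read-out beyond the usual scatter. Nothing measured here explains the difference.

The compounds shown leave open whether other groups at this place, such as an ethyl ester or a primary amide, would read closer to compound 2 or to compound 3. They also leave open whether the same change from methoxycarbonyl to carboxy would give a similar step on compound 1, which carries a different group on its other side.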